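The source may hold more compounds than are shown below. What is called first, only, known or untested is meant among the compounds shown, and "the series" means these compounds.

Measured compounds:
- compound 1, `Cc1cc(OCc2c(-c3c(Cl)cccc3Cl)noc2C(C)C)ncc1[N+](=O)[O-]`: 58%
- compound 2, `Cc1cc(OCc2c(-c3c(Cl)cccc3Cl)noc2C(C)C)nc2ccccc12`: 40%
- compound 3, `CN(Cc1cccc(C(=O)O)c1)c1ccc(OCc2c(-c3c(Cl)cccc3Cl)noc2C2CC2)nc1C(F)(F)F`: 79%

All three compounds share a core and were tested in a functional assay on HEK293 cells for agonist activity at Bile acid receptor (Homo sapiens); on this read-out lower numbers stand for smaller maximal responses and higher numbers for larger maximal responses. Compound 3 gives the highest of the three numbers in this assay, with 79%. Compound 1, the nearest, is lower by a gap beyond the scatter, and compound 2 is lower still, also by a gap beyond the scatter.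

Compound 4, `CC(Oc1ccc(C(=O)O)cc1)c1ccc(OCc2c(-c3c(Cl)cccc3Cl)noc2C2CC2)nc1C(F)(F)F`, has not yet been measured. It differs from compound 3 in one place: 1-(4-carboxyphenoxy)ethyl in place of (3-carboxybenzyl)(methyl)amino on an aromatic carbon. The group that leaves and the group that enters are of the same size, and each carries one carboxylic acid, one hydrogen-bond donor and two hydrogen-bond acceptors.

Within the data shown here, no single-change step between measured compounds is known here, so nothing in the numbers says how much such a swap moves the maximal response. The expectation for compound 4 in this assay is therefore a small step, a number 5 percentage points lower from compound 3 to compound 4 (within the scatter), not clearly beyond the scatter in either direction. Compound 4 is estimated at 74%, with a range from 52% to 96%.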

Compound 4, largest response reached (reported as efficacy), in percent of the reference or control that the assay uses: 70%
Compound 4: middle estimate off by 4 percentage points, on the high side; the measured number falls inside the stated range.
By their numbers in this assay, from the lowest: compound 2; then compound 1; then compounds 4 and 3 (each within the scatter of the next).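

In this assay, putting 1-(4-carboxyphenoxy)ethyl in place of (3-carboxybenzyl)(methyl)amino gives a number 9 percentage points lower from compound 3 to compound 4 (within the scatter), the first single-place step available in this set. At this aromatic carbon, ortho to a trifluoromethyl group, the side chain can therefore be rebuilt substantially without a shift in maximal response that stands clear of the scatter: attachment through nitrogen gives way to attachment through carbon, an oxygen enters the chain, and the acid goes from a 3-carboxy to a 4-carboxy arrangement. Nothing available here explains why the response stays within the scatter.

Since these changes arrive together in one step, the compounds shown cannot separate their individual contributions, and opposing effects that happen to cancel remain possible. As far as these compounds go, both groups also carry a carboxylic acid, so the role of that acid at this position stays open, and a side chain ending in a primary amide or a nitrile instead would be needed to address it.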